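A few compounds are considered here, and "the series" means these few. Any claim that something is new, unique, unknown or untested is made for them only; others in the source may bear on it.

Working notes on the series in an assay on cells with melanin-concentrating hormone receptor 1 (Homo sapiens) as the target, read by radioligand binding; a lower number here means a stronger inhibitor, a higher number a weaker inhibitor.

Two compounds carry measured numbers. Compound 1 `CCCOc1cccc2ccc(N)nc12` gives 1100 nM in this assay. Compound 2 `COC(C)(C)CCOc1cccc2ccc(N)nc12` gives 132 nM in this assay, which is the lowest of the two numbers shown; the only neighbour is compound 1, and the step of an 8.3-fold lower number from compound 1 to compound 2 (0.92 log units; beyond the scatter) came with 1-methoxy-1-methylethyl in place of methyl on a saturated chain carbon, two bonds along the chain from an oxygen on an aromatic ring.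

Compound 3 `COCCOCCOc1cccc2ccc(N)nc12` has not been measured in this assay. Its change from compound 2 is 2-methoxyethoxy in place of 1-methoxy-1-methylethyl on a saturated chain carbon, two bonds along the chain from an oxygen on an aromatic ring.

Within the data shown here, only the step from compound 1 to compound 2 bears on this, and it is indirect: it shows that lengthening the chain with an extra ether oxygen gave a modest improvement, but it says nothing about giving up the 1-methoxy-1-methylethyl branching for a straight 2-methoxyethoxy chain. Compound 3 keeps the ether oxygens of compound 2, so a number near compound 2, or a modest drift back towards compound 1, is expected; the expected step is a 2.3-fold higher number from compound 2 to compound 3 (0.36 log units; beyond the scatter). The estimate for compound 3 is 300 nM, with a range from 100 nM to 900 nM.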

Compound 3, half-maximal inhibitory concentration: > 2000 nM
Compound 3: only a limit was reported; the forecaster's own chance of this, stated with the estimate: 3%; middle value at least 6.6-fold (0.82 log units) away from the limit.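

The reading for compound 3 in this assay is a limit of the assay and not a number: the limit of > 2000 nM in this assay, at which 1 of the 3 values shown sits.

Exchanging 1-methoxy-1-methylethyl for 2-methoxyethoxy gives an at least 15-fold higher number from compound 2 to compound 3 (1.18 log units; beyond the scatter), even though both groups have 5 heavy atoms and both contain a methoxy unit, so the gain seen in an 8.3-fold lower number from compound 1 to compound 2 (0.92 log units; beyond the scatter) does not extend to every ether-bearing group of this size at this position on a saturated chain carbon. Set against the methyl group, the new group gives an at least 1.8-fold higher number from compound 1 to compound 3 (0.25 log units; that floor lies within the scatter), which shows no gain from 2-methoxyethoxy and sets no firm order between these two compounds.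

The compounds shown do not separate the branching of 1-methoxy-1-methylethyl from the exchange of a chain carbon for the second ether oxygen, since the two changes arrive together in a single step. From the compounds shown here alone, whether an unbranched 3-methoxybutyl chain, a plain hydrocarbon chain of similar length such as pentyl, or a terminal amine or carboxylic acid would keep the number of compound 2 in this assay stays open.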